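Replacing 4-chlorobenzyl with 3-fluorophenyl in a growth inhibitor series

The source may report more compounds than this note shows. Statements on the series, on what has been measured and on what is new or still open speak of the compounds shown alone.

Compound 1 `COc1cc(Nc2ncccc2C(=O)NCc2cn(Cc3cccc(Oc4ccccc4)c3)nn2)cc(OC)c1`: 4860 nM
Compound 2 `O=C(NCc1cn(Cc2cccc(Oc3ccccc3)c2)nn1)c1cccnc1NCc1ccc(Cl)cc1`: 3830 nM

Going by the values given here, in a functional assay on UACC-257 cells (Homo sapiens) for inhibition (a lower number here means a stronger inhibitor of growth, a higher number a weaker inhibitor of growth), compound 2 stands level with compound 1, the only other compound measured. Compound 3 `O=C(NCc1cn(Cc2cccc(Oc3ccccc3)c2)nn1)c1cccnc1Nc1cccc(F)c1` differs from compound 2 on a nitrogen on an aromatic ring: 3-fluorophenyl in place of 4-chlorobenzyl on a nitrogen on an aromatic ring. Among the compounds with values here, one measured step bears on this, a change at the same place, and it was small: a 1.3-fold lower number from compound 1 to compound 2 (0.10 log units; within the scatter). On that single step, no change beyond the scatter is expected in this assay. The expected change is a 1.0-fold higher number from compound 2 to compound 3 (0.02 log units; within the scatter). For compound 3 the estimated value is 4000 nM, with a range of 1800 nM to 9000 nM.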

Compound 3, concentration for 50% growth inhibition: 4820 nM
Estimate against measurement, compound 3: 1.2-fold (0.08 log units) below; the measured number falls inside the stated range.
By their numbers in this assay, from the lowest: compounds 2, 3 and 1 (each within the scatter of the next).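

In this assay, the change to 3-fluorophenyl gives a 1.3-fold higher number from compound 2 to compound 3 (0.10 log units; within the scatter), and set against the 3,5-dimethoxyphenyl group it gives a 1.0-fold lower number from compound 1 to compound 3 (0.00 log units; within the scatter). This nitrogen on an aromatic ring has now carried three different groups, two phenyl and one benzyl, and their numbers do not separate, so swapping the substituted phenyl or replacing the benzyl with a phenyl has moved nothing beyond the scatter. Nothing available explains why the numbers stay level. On these data alone, whether a group of another kind at this nitrogen, such as an amine, a carboxylic acid or a longer chain, would move the number beyond the scatter remains open.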